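Stability notes: from compound 2 to compound 4

This account rests on a few compounds, and the source may have more. Where it says the series, first, only, none or still open, it means among the compounds named here.

Of the compounds shown here, three have numbers so far in an ADME assay on S9 fraction from liver (Homo sapiens) for metabolic stability, read by LC-MS, with a stated time of 5 min, tested at 1 uM; a higher number here means that more of the compound is left, a lower number that less of the compound is left. Compound 2 `CC(=O)Nc1onc(-c2ccc(F)cc2)c1-c1ccncc1` stands highest of the three at 92.4%. Compound 1 `Fc1ccc(-c2n[nH]c(CCCc3ccccc3)c2-c2ccncc2)cc1` gives 81.5%, which lies below compound 2 by more than the scatter. Compound 3 `O=C(Nc1onc(Nc2ccc(F)cc2)c1-c1ccncc1)c1ccccc1` gives 39.6%, the furthest from compound 2 and also beyond the scatter.

Compound 4 `O=C(CCc1ccccc1)Nc1onc(-c2ccc(F)cc2)c1-c1ccncc1` has not yet been measured. It differs from compound 2 in one place, benzyl in place of hydrogen on a saturated chain carbon bound to a carbonyl carbon. Cut one bond further out, the same difference reads methyl to phenethyl.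

Going by the values given here, no measured pair isolates this change, so any expectation in this assay rests on indirect comparison. Compound 1 at 81.5% and compound 3 at 39.6% each hold an unsubstituted phenyl group, and both lie under compound 2, but they are far apart and differ from it in more than one place. The expected change is a fall beyond the scatter, estimated as a number 30.4 percentage points lower from compound 2 to compound 4 (beyond the scatter), with its size poorly defined. For compound 4 the estimated value is 62%, with an expected range from 35% to 85%.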

Compound 4, percent of the compound remaining: 32.1%
The estimate for compound 4 lay 29.9 percentage points above the measured number; the whole stated range lies above it.
By their numbers in this assay, from the lowest: compounds 4 and 3 (each within the scatter of the next); then compound 1; then compound 2.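

In this assay, going by these compounds alone, the change of benzyl in place of hydrogen on a saturated chain carbon bound to a carbonyl carbon, which reads methyl to phenethyl when cut one bond further out, gives a number 60.3 percentage points lower from compound 2 to compound 4 (beyond the scatter) and makes this the first direct reading at this position. Neither compound 1 nor compound 3 could give such a reading, as neither differs from compound 2 in one place only; this single change is now seen to leave much less of the compound remaining, so the position is not indifferent to what is added there. No measurement at hand bears on why the step arises.

Within the data shown here, the single step does not separate the added chain length from the added six-membered aromatic ring, so it remains open which part of the phenethyl group goes with the fall. From the compounds shown here alone, whether an ethyl group, a phenyl group, or a chain ending in an amine or a carboxylic acid at this place would leave more of the compound remaining in this assay is also open.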